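Pyridinyl switch on the sulfonyl-bearing core

A few compounds are considered here, and "the series" means these few. Any claim that something is new, unique, unknown or untested is made for them only; others in the source may bear on it.

Compound 3 `N#Cc1ccc(S(=O)(=O)N2C/C(=C\c3cccnc3)C(=O)/C(=C/c3ccccc3C(F)(F)F)C2)cc1` gives 6150 nM in a functional assay on QGY-7703 cells (Homo sapiens) for cytotoxicity, read by MTT assay, with a stated time of 24 h (on this read-out lower numbers stand for stronger inhibition and higher numbers for weaker inhibition), the highest of the three numbers, though only by a margin within the scatter of compound 2. Compound 2 `O=C1/C(=C/c2cccnc2)CN(S(=O)(=O)c2ccc(F)cc2)C/C1=C\c1ccccc1C(F)(F)F` gives 6030 nM; the step of a 1.0-fold higher number from compound 2 to compound 3 (0.01 log units; within the scatter) is within the scatter. Compound 1 `CN1C/C(=C\c2cccnc2)C(=O)/C(=C/c2ccccc2C(F)(F)F)C1` gives 2910 nM; the steps of a 2.1-fold higher number from compound 1 to compound 2 (0.32 log units; beyond the scatter) and a 2.1-fold higher number from compound 1 to compound 3 (0.32 log units; beyond the scatter) are modest and beyond the scatter. Compound 4 `N#Cc1ccc(S(=O)(=O)N2C/C(=C\c3ccncc3)C(=O)/C(=C/c3ccccc3C(F)(F)F)C2)cc1` is not yet measured; it differs from compound 3 by pyridin-4-yl in place of pyridin-3-yl on a double-bonded chain carbon bound to a double-bonded ring carbon. For the measured compounds named here, none of the measured steps bears on this change: all three concern the group on the amine nitrogen in the ring. Going by the values given here, with no informative step, no shift beyond the scatter is expected in either direction, and the estimated step is a 1.0-fold lower number from compound 3 to compound 4 (0.01 log units; within the scatter). Compound 4 is therefore expected near 6000 nM, between 2500 nM and 15000 nM.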

Compound 4, half-maximal inhibitory concentration: 6290 nM
Compound 4: the middle estimate sits 1.0-fold (0.02 log units) below what was measured; measured number inside the range.
By their numbers in this assay, from the lowest: compound 1; then compounds 2, 3 and 4 (each within the scatter of the next).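

In this assay, pyridin-4-yl in place of pyridin-3-yl on a double-bonded chain carbon bound to a double-bonded ring carbon gives a 1.0-fold higher number from compound 3 to compound 4 (0.01 log units; within the scatter) and so stays within the scatter. For the compounds shown here, this is the first reading at this position, and with (4-cyanophenyl)sulfonyl on the amine nitrogen in the ring, the two pyridinyl groups cannot be told apart. No measured evidence bears on this result.

Still open, from the compounds shown here alone, is whether the same swap reads alike with methyl on that nitrogen, as in compound 1. Also open, going by these compounds, is whether pyridin-2-yl at this position stays within the scatter of compound 3 and compound 4.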